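A Piperidine Urea on the Sulfonamide Arm

The compounds below may be only part of what the source reports. "The series", "measured", "known", "first", "only" and "open" are said of these compounds alone.

Compound 2 `NC(=O)Nc1ccc(S(=O)(=O)Nc2cccc(-c3nc(-c4ccc(NC(=O)c5cccnc5)cc4Cl)no3)c2)cc1` carries a ureido group on the aryl sulfonamide of the shared core, and in a functional assay on MDA-MB-231 cells (Homo sapiens) for antiproliferative activity, read by MTT assay, with a stated time of 72 h (a higher number here means a weaker inhibitor, a lower number a stronger inhibitor), compound 2 gives 2800 nM. For the measured compounds named here, it is the only number in this set. Compound 1 `NS(=O)(=O)c1ccc(S(=O)(=O)Nc2cccc(-c3nc(-c4ccc(NC(=O)c5cccnc5)cc4Cl)no3)c2)cc1`, which bears a sulfamoyl group in that place, reaches only a limit of the assay rather than a number: in this assay compound 1 gives > 10000 nM, which is the limit of > 10000 nM in this assay, at which 1 of the 2 values shown sits. Going by the values given here, the one measured step, an at least 3.5-fold lower number from compound 1 to compound 2 (0.55 log units; beyond the scatter), therefore shows that exchanging sulfamoyl for ureido improves the readout at least modestly.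

Compound 3 `O=C(Nc1ccc(-c2noc(-c3cccc(NS(=O)(=O)c4ccc(NC(=O)N5CCCCC5)cc4)c3)n2)c(Cl)c1)c1cccnc1` differs from compound 2 at the carbonyl carbon whose other neighbours are amide-type nitrogen: piperidin-1-yl in place of amino on a carbonyl carbon. Among the compounds with values here, no measured step touches this carbonyl carbon; the single step in hand concerns the group on the aromatic carbon. The expectation is thus anchored only on compound 2 at 2800 nM and leaves either direction open. Compound 3 is expected to lie near its parent, with a step of a 1.1-fold higher number from compound 2 to compound 3 (0.03 log units; within the scatter) expected to stay within the scatter. The estimate for compound 3 is 3000 nM, between 1000 nM and 10000 nM.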

Compound 3, half-maximal inhibitory concentration: > 10000 nM
Compound 3 ended at the assay's limit; the forecaster's own chance of this, stated with the estimate: 20%; middle value at least 3.3-fold (0.52 log units) away from the limit.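

Exchanging amino for piperidin-1-yl on a carbonyl carbon gives an at least 3.5-fold higher number from compound 2 to compound 3 (0.55 log units; beyond the scatter) in this assay, so the ureido group's advantage over sulfamoyl does not carry over to this substituted form, and the group on this carbonyl carbon matters for the readout. As far as these compounds go, compound 3 gives > 10000 nM, which is a limit of the assay and not a number, so the full size of the loss stays unknown. The step between compound 1 and compound 3 cannot be read, and the series now has two compounds without a number, leaving compound 2 as the only one with a measured value: the limit of > 10000 nM in this assay, at which 2 of the 3 values shown sit.

From the compounds shown here alone, the change both adds a six-membered non-aromatic ring and removes the hydrogen-bond donor of the amino group, and these compounds cannot separate the two, so it remains open whether methylamino or dimethylamino on the same carbonyl carbon would keep the readout of compound 2 or lose it as well. Also open, going by these compounds, is how a morpholin-4-yl ring, which brings a ring oxygen, would behave in this place, and whether any group here could bring the readout below that of compound 2.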